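Compound 3 to Compound 4: A Carbon Ring Enters

A few compounds are considered here, and "the series" means these few. Any claim that something is new, unique, unknown or untested is made for them only; others in the source may bear on it.

Of the compounds shown here, three sharing one core have been measured in a physicochemical assay for lipophilicity, read by HPLC, at pH 7.5; on this read-out lower numbers stand for lower lipophilicity and higher numbers for higher lipophilicity. Compound 1 `CCOc1ccccc1-c1ccc(-c2nc3cnccc3c(N)c2C#N)cc1` gives 3. Compound 2 `CCCCC(Nc1c(C#N)c(-c2ccc(-c3ccccc3OCC)cc2)nc2cnccc12)C(N)=O`, with 1-carbamoylpentyl on the nitrogen, gives 3.6. Compound 3 `CCOc1ccccc1-c1ccc(-c2nc3cnccc3c(N[C@H](CC)C(N)=O)c2C#N)cc1`, with 1-carbamoylpropyl there, gives 3. Compound 3 is thus level with compound 1 at the digits shown, and the two share the lowest number of the three, while compound 2 has the highest.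

Compound 4 `CCOc1ccccc1-c1ccc(-c2nc3cnccc3c(NC(C(N)=O)C3CC3)c2C#N)cc1` has not been measured. Its change from compound 3 is a group of 7 heavy atoms (5 carbon, 1 nitrogen, 1 oxygen; one three-membered non-aromatic ring of carbon only) in place of a group of 6 heavy atoms (4 carbon, 1 nitrogen, 1 oxygen; no ring), on a nitrogen on an aromatic ring. Going by the values given here, three measured steps bear on it, all at the same nitrogen. Placing 1-carbamoylpropyl there gave no change at the digits printed from compound 1 to compound 3 (within the scatter), and placing 1-carbamoylpentyl there gave a number 0.60 log units higher from compound 1 to compound 2 (beyond the scatter). Exchanging the longer group for the shorter gave a number 0.60 log units lower from compound 2 to compound 3 (beyond the scatter). Among the compounds with values here, the entering group is closer in size to 1-carbamoylpropyl than 1-carbamoylpentyl is, although no measured step introduces a three-membered ring. A small upward step, probably within the scatter and well short of the step to compound 2, is therefore expected in this assay. The estimated change is a number 0.20 log units higher from compound 3 to compound 4 (within the scatter). The estimate for compound 4 is 3.2, with an expected range of 2.8 to 3.6.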

Compound 4, distribution coefficient: 3
Beside the measured number, compound 4's estimate is 0.20 log units above it, within the range that was stated.
By their numbers in this assay, from the lowest: compounds 1, 3 and 4 (each within the scatter of the next); then compound 2.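

At the nitrogen on an aromatic ring, this assay now covers a group with a three-membered non-aromatic ring of carbon only. In place of a hydrogen atom, this group gave no change at the digits printed from compound 1 to compound 4 (within the scatter), and in place of 1-carbamoylpropyl it gave no change at the digits printed from compound 3 to compound 4 (within the scatter), so the extra ring carbon and the ring itself left the read-out level in this one case. Cyclopropyl in place of butyl gave a number 0.60 log units lower from compound 2 to compound 4 (beyond the scatter), which leaves compound 2, with its 1-carbamoylpentyl group, as the only one of the four compounds set apart from the rest, and no available evidence accounts for these numbers.

The compounds shown leave open whether a larger carbon ring such as cyclohexyl, or a chain of intermediate length such as 1-carbamoylbutyl, would stay level with compound 4 or move towards compound 2. They also leave open what would happen if a carboxylic acid or an amine replaced the primary amide, and whether the single forms of the cyclopropyl-bearing group, which has no defined stereocentre in compound 4, would read alike in this assay.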